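The source may report more compounds than this note shows. Statements on the series, on what has been measured and on what is new or still open speak of the compounds shown alone.

Working notes on the series

Of the compounds shown here, two have numbers so far. Compound 1 `CN1CCN(C(=O)/C=C/c2ccncc2-c2ccc3ccccc3c2)CC1` stands at the lower of the two in an assay on a protein complex for inhibition of CDK8/Cyclin C (Homo sapiens), with a stated time of 1 h (a higher number here means a weaker inhibitor, a lower number a stronger inhibitor), where compound 1 gives 43.6 nM. Compound 2 `CCOC(=O)/C=C/c1ccncc1-c1ccc2c(cnn2C)c1`, which carries a different ester end and a different fused ring, gives 102 nM in this assay; the gap between compound 2 and compound 1 is beyond the scatter, so compound 1 is the stronger inhibitor of the two on the numbers shown. Compound 3 `O=C(/C=C/c1ccncc1-c1ccc2ccccc2c1)N1CCOCC1` is the next one to be measured. It differs from compound 1 in one place: morpholin-4-yl in place of 4-methylpiperazin-1-yl on a carbonyl carbon. Going by the values given here, no pair of measured compounds isolates this change, so there is nothing to read a step from; the change is small in what it counts, and the expectation is for no step beyond the scatter, or a modest one toward a weaker inhibitor. For compound 3 in this assay the estimated value is 65 nM, with a range of 25 nM to 170 nM. That amounts to an expected step of a 1.5-fold higher number from compound 1 to compound 3 (0.17 log units; within the scatter).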

Compound 3, half-maximal inhibitory concentration: 60.3 nM
Beside the measured number, compound 3's estimate is 1.1-fold (0.03 log units) above it; the measured number falls inside the stated range.
By their numbers in this assay, from the lowest: compounds 1, 3 and 2 (each within the scatter of the next, the first and the last beyond it).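

In this assay, going by these compounds alone, morpholin-4-yl in place of 4-methylpiperazin-1-yl on a carbonyl carbon gives a 1.4-fold higher number from compound 1 to compound 3 (0.14 log units; within the scatter), the first step that can be read from a single difference. On this pair, the assay does not separate the two six-membered rings, which have the same count of hydrogen-bond donors and acceptors, so this position accepts either ring within the scatter. Nothing measured bears on what lies behind this result.

From the compounds shown here alone, whether the same holds for an open-chain amine such as dimethylamino, or for a carboxylic acid, on that carbonyl carbon remains open. Compound 2 differs from compound 1 in both its ester end and its fused ring, so the contribution of each to its number cannot be read.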